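The source may report more compounds than this note shows. Statements on the series, on what has been measured and on what is new or still open speak of the compounds shown alone.

In a functional assay on a cell-free system (plasma, Homo sapiens), with a stated time of 3 min (a lower number here means a stronger inhibitor, a higher number a weaker inhibitor), compound 1 (`O=C(NCc1cc(Cl)ccc1-n1cnnn1)[C@@H]1C[C@@H]2C[C@@H]2N1C(=O)[C@H](O)c1cccc(Cl)c1`) gives 1000 nM and compound 2 (`CC(C)(C)[C@@H](O)C(=O)N1OCC[C@H]1C(=O)NCc1cc(Cl)ccc1-n1cnnn1`) gives 1600 nM, so the two values lie within the scatter of each other. Compound 3 (`CC(C)(C)[C@@H](O)C(=O)N1[C@H](C(=O)NCc2cc(Cl)ccc2-n2cnnn2)C[C@@H]2C[C@@H]21`), not yet measured, has tert-butyl in place of 3-chlorophenyl on a saturated chain carbon bound to a carbonyl carbon and an oxygen on a saturated carbon. Among the measured compounds shown here, no measured pair isolates this change. For the measured compounds named here, compound 2, which also carries tert-butyl, gives 1600 nM and is the only guide. The estimated step is a 1.1-fold lower number from compound 1 to compound 3 (0.05 log units; within the scatter) in this assay and is expected to stay within the scatter. For compound 3 the expected value is 900 nM with an estimated range from 200 nM to 4000 nM for the measurement.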

Compound 3, half-maximal inhibitory concentration: 1500 nM
The estimate for compound 3 lay 1.7-fold (0.22 log units) below the measured number; measured number inside the range.
By their numbers in this assay, from the lowest: compounds 1, 3 and 2 (each within the scatter of the next).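

The read-out shows a 1.5-fold higher number from compound 1 to compound 3 (0.18 log units; within the scatter) in this assay for tert-butyl in place of 3-chlorophenyl on a saturated chain carbon bound to a carbonyl carbon and an oxygen on a saturated carbon. This one-place pair shows that, on the core of compound 1, the six-membered aromatic ring is not required for a value of this size. Nothing available bears on a reason for this result. From the compounds shown here alone, whether an amine or a carboxylic acid at this position would also stay within the scatter remains open.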